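The source may report more compounds than this note shows. Statements on the series, on what has been measured and on what is new or still open speak of the compounds shown alone.

Working notes on the series.

Compound 1 `CC1=C(C(=O)NC(C)C)C(c2ccco2)NC(=O)N1` stands lowest of the three measured compounds in an assay on membranes from HEK293 cells for displacement of a labelled ligand from adenosine receptor A2b (Homo sapiens), read by scintillation counting, with a stated time of 30 min, tested at 1 uM (on this read-out higher numbers stand for more inhibition at the one concentration tested (going by the name of the read-out) and lower numbers for less inhibition), where compound 1 gives 2%. Compound 2 `CC1=C(C(=O)NC(C)C)C(c2cccs2)NC(=O)N1` gives 40%, and compound 3 `CC1=C(C(=O)NC(C)C)C(c2ccsc2)NC(=O)N1` gives 3%. The step of a number 38 percentage points higher from compound 1 to compound 2 (beyond the scatter) is the one large movement among the measured compounds, while a number 1 percentage points higher from compound 1 to compound 3 (within the scatter) stays within the scatter; between the two thiophenes, a number 37 percentage points lower from compound 2 to compound 3 (beyond the scatter) again runs large.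

Compound 4 `CCSC(=O)C1=C(C)NC(=O)NC1c1ccco1` differs from compound 1 in one place: ethylsulfanyl in place of isopropylamino on a carbonyl carbon. Within the data shown here, every measured step concerns the aryl group on the saturated ring carbon; none touches the carbonyl carbon, so no measured step bears on this change. Among the measured compounds shown here, compound 1 already sits near the bottom of the scale, and nothing among the measured compounds indicates which way a change at the carbonyl carbon moves the read-out.

Compound 4 is therefore expected to stay within the scatter of compound 1, with an estimated step of a number 4 percentage points higher from compound 1 to compound 4 (within the scatter). The estimate for compound 4 is 6%, with a range from 0% to 25%.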

Compound 4, a percentage reported as inhibition, at one concentration (the size of the read-out at that concentration, not a potency): 29%
Compound 4: the middle estimate sits 23 percentage points below what was measured; measured number outside the range, above it.
By their numbers in this assay, from the lowest: compounds 1 and 3 (each within the scatter of the next); then compound 4; then compound 2.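

The carbonyl carbon is not a silent position: in this assay, ethylsulfanyl in place of isopropylamino gives a number 27 percentage points higher from compound 1 to compound 4 (beyond the scatter), so the read-out responds to this group as well as to the aryl group on the saturated ring carbon. The furan-2-yl group stays in place throughout this step, so the movement belongs to the change at the carbonyl carbon alone. The change swaps a nitrogen for a sulfur and loses the amide hydrogen, and no measurement shown bears on what lies behind the step.

On these data alone, it remains open whether ethylsulfanyl moves the read-out in the same way when thiophen-2-yl or thiophen-3-yl sits on the saturated ring carbon. Ethylamino, ethoxy or methylsulfanyl on the same carbonyl carbon would show whether the sulfur or the chain carries the step.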